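The compounds below may be only part of what the source reports. "The series", "measured", "known", "first", "only" and "open" are said of these compounds alone.

Two close relatives of a shared core have been tested for their effect on the growth of a human tumour cell line, and a third awaits its measurement. Compound 1 `CCOC(=O)C[C@H]1[C@@H](O[Si](C)(C)C(C)(C)C)[C@H](n2cnc3c(NC(=O)Nc4ccccc4)ncnc32)O[C@@H]1COC(=O)NC` and compound 2 `CNC(=O)NC[C@H]1O[C@@H](n2cnc3c(NC(=O)Nc4ccccc4)ncnc32)[C@H](O[Si](C)(C)C(C)(C)C)[C@@H]1CC(=O)N(C)OC` differ in more than one place, so their numbers are simply set side by side. In a functional assay on SF-539 cells (Homo sapiens) for antiproliferative activity (a higher number here means a weaker inhibitor of growth, a lower number a stronger inhibitor of growth), compound 1 gives 11.5 nM. In this assay, going by the values given here, compound 2 gives 22.3 nM, the higher of the two numbers measured so far, though its gap to compound 1 lies within the usual scatter, so the two cannot be told apart as inhibitors of growth.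

Compound 3 `CCOC(=O)C[C@H]1[C@@H](O[Si](C)(C)C(C)(C)C)[C@H](n2cnc3c(NC(=O)Nc4ccccc4)ncnc32)O[C@@H]1CNC(=O)NC` is reached from compound 2 by a single change at one carbonyl carbon: ethoxy in place of methoxy(methyl)amino on a carbonyl carbon. Among the compounds with values here, no pair of measured compounds shows this same exchange, so its effect can only be guessed from the two numbers at hand. The expectation is that the step of a 1.1-fold lower number from compound 2 to compound 3 (0.05 log units; within the scatter) stays within the scatter, with no clear direction. On that basis, compound 3 is estimated to give 20 nM in this assay, with a plausible range from 8 nM to 50 nM.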

Compound 3, concentration for 50% growth inhibition: 5.19 nM
Estimate against measurement, compound 3: 3.9-fold (0.59 log units) above; measured number outside the range, below it.
By their numbers in this assay, from the lowest: compound 3; then compounds 1 and 2 (each within the scatter of the next).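

In this assay, putting ethoxy in place of methoxy(methyl)amino on a carbonyl carbon gives a 4.3-fold lower number from compound 2 to compound 3 (0.63 log units; beyond the scatter), the first clear sign that the group at this carbonyl carbon affects the number, since the earlier pair differed in more than one place and could not isolate it. A second single change, elsewhere on the molecule, also matters: (methylcarbamoyl)amino in place of (methylcarbamoyl)oxy on a saturated chain carbon bound to a saturated ring carbon gives a 2.2-fold lower number from compound 1 to compound 3 (0.35 log units; beyond the scatter). Both steps are modest and both end at compound 3, which, at 5.19 nM, has the lowest number of the three and carries both ethoxy and (methylcarbamoyl)amino.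

No measurement accompanying these numbers explains either step, so the reason for them stays open. Also open, as far as these compounds go, is how other groups would fare on the same carbonyl carbon, such as a hydroxyl, which would give a carboxylic acid, a simple amine, which would give an amide, or a longer chain such as butoxy.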